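Replacing the 3-acetamidophenyl group of compound 2

The source may report more compounds than this note shows. Statements on the series, on what has been measured and on what is new or still open speak of the compounds shown alone.

Measured in a functional assay on HL-60 cells (Homo sapiens) for inhibition, read by MTT assay, with a stated time of 72 h; a higher number here means a weaker inhibitor, a lower number a stronger inhibitor:
compound 1 `Cc1nc(-c2ccccc2)c(C(=O)N2CCN(c3c(C)cccc3C)CC2)o1`: 146 nM
compound 2 `CC(=O)Nc1cccc(N2CCN(C(=O)c3oc(C)nc3-c3ccccc3)CC2)c1`: 329 nM

Of these two numbers, compound 2 holds the higher, 329 nM, which makes it the weaker inhibitor of the pair in this assay. Compound 3 `Cc1nc(-c2ccccc2)c(C(=O)N2CCN(c3ccc(Cl)c(Cl)c3)CC2)o1` carries 3,4-dichlorophenyl in place of 3-acetamidophenyl on an amine nitrogen in a ring. The change counts as follows: 3,4-dichlorophenyl in place of 3-acetamidophenyl on an amine nitrogen in a ring. Within the data shown here, only one measured step bears on this place, the modest 2.3-fold higher number from compound 1 to compound 2 (0.35 log units; beyond the scatter), which brought in the 3-acetamidophenyl group that now leaves. A similarly modest fall is therefore expected, a 1.8-fold lower number from compound 2 to compound 3 (0.26 log units; within the scatter). Compound 3 is estimated at 180 nM, with an expected range of 60 nM to 500 nM.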

Compound 3, half-maximal inhibitory concentration: 124 nM
For compound 3 the middle estimate is 1.5-fold (0.16 log units) above the measured one; low and high end bracket the measured number.
By their numbers in this assay, from the lowest: compounds 3 and 1 (each within the scatter of the next); then compound 2.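

In this assay the result shows that this position accepts 3,4-dichlorophenyl, with no hydrogen-bond donor or acceptor, in place of 3-acetamidophenyl, giving a 2.7-fold lower number from compound 2 to compound 3 (0.42 log units; beyond the scatter). The a 1.2-fold lower number from compound 1 to compound 3 (0.07 log units; within the scatter) leaves 3,4-dichlorophenyl and 2,6-dimethylphenyl indistinguishable on this amine nitrogen, although their substituents differ in identity and placement. No measured evidence accounts for these differences or their absence. The compounds shown leave open whether an aromatic ring is needed here, since a cyclohexyl or simple methyl group on this nitrogen would test that, and how a carboxylic acid on the phenyl ring would fare.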